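Two methoxy groups in place of one hydroxy group

The compounds below may be only part of what the source reports. "The series", "measured", "known", "first", "only" and "open" are said of these compounds alone.

Of the compounds shown here, three sharing one core have been measured in a functional assay for antagonist activity at Alpha-1A adrenergic receptor (Oryctolagus cuniculus); on this read-out higher numbers stand for weaker binding and lower numbers for tighter binding. Compound 1 `CNC(=O)c1cccnc1NCCCN1CCN(c2ccccc2OC)CC1` gives 1 nM, compound 2 `CN(C)C(=O)c1cccnc1NCCCN1CCN(c2ccccc2O)CC1` gives 5.01 nM, and compound 3 `CN(C)C(=O)c1cccnc1NCCCN1CCN(c2ccccc2-c2ccccc2)CC1` gives 1.26 nM. Compound 2 thus stands with the highest number of the three: compound 3 is nearest to it and compound 1 lies furthest from it. Within the data shown here, the one single-point step recorded is a 4.0-fold lower number from compound 2 to compound 3 (0.60 log units; beyond the scatter).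

Compound 4 `COc1ccc(N2CCN(CCCNc3ncccc3C(=O)N(C)C)CC2)c(OC)c1` has not yet been measured. It differs from compound 2 as follows: 2,4-dimethoxyphenyl in place of 2-hydroxyphenyl on an amine nitrogen in a ring. Among the measured compounds shown here, only the step from compound 2 to compound 3 bears directly on this change, since it alters the same group on the same ring nitrogen, and it was modest in size. Compound 1 carries a methoxy group rather than a hydroxy group but also a differently substituted amide, so its lower number cannot be assigned to one cause. Together these numbers suggest that leaving the hydroxy of compound 2 lowers the number in this assay, though compound 4 adds a second methoxy that no measured compound carries. Compound 4 is therefore expected to give 2 nM, within a range of 0.6 nM to 8 nM. The expected step is a 2.5-fold lower number from compound 2 to compound 4 (0.40 log units; beyond the scatter).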

Compound 4, dissociation constant: 31.6 nM
The estimate for compound 4 lay 16-fold (1.20 log units) below the measured number; the measured number lies above the stated range.
By their numbers in this assay, from the lowest: compounds 1 and 3 (each within the scatter of the next); then compound 2; then compound 4.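

In this assay the group on the ring nitrogen of compound 2 now moves the number in both directions, with a 6.3-fold higher number from compound 2 to compound 4 (0.80 log units; beyond the scatter) for the change to 2,4-dimethoxyphenyl, against a 4.0-fold lower number from compound 2 to compound 3 (0.60 log units; beyond the scatter) for phenyl in place of hydroxy. Losing the hydroxy of compound 2 therefore does not by itself lower the number, since compound 3 and compound 4 both lack it and yet lie on opposite sides of compound 2. What counts at this position is what takes the place of the hydroxy, and the one change shown to raise the number is the one that brings in two methoxy groups.

Going by these compounds, the step to compound 4 replaces the hydroxy with a methoxy group and adds a second methoxy group in a single change, leaving the share of each unresolved, and it remains open how a fluorine atom or an amino group on that aromatic ring would read on the same core. Nothing available here bears on why the number rose with this change.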